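Aryl halogen swap on the thiazoline benzamide series

A few compounds are considered here, and "the series" means these few. Any claim that something is new, unique, unknown or untested is made for them only; others in the source may bear on it.

Two compounds carry numbers in a functional assay on MDA-MB-231 cells (Homo sapiens), read by microscopy and transwell migration, with a stated time of 24 h; on this read-out higher numbers stand for weaker inhibition and lower numbers for stronger inhibition. Compound 1 `CCN(C(=O)c1ccccc1)c1nc(-c2ccccc2)cs1` gives 533 nM in this assay. Compound 2 `Cn1c(-c2ccccc2Cl)cs/c1=N\C(=O)c1ccccc1` gives 268 nM in this assay. Compound 2 stands at one end of the two numbers and compound 1 at the other, and the two values sit within the scatter of each other, so nothing separates them beyond repeat-measurement noise. Within the data shown here, no step between measured compounds is available on which to size the effect of a structural change.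

Compound 3 `Cn1c(-c2cccc(Br)c2)cs/c1=N\C(=O)c1ccccc1` is the next compound to be measured in this assay. Against compound 2 it differs in one place: 3-bromophenyl in place of 2-chlorophenyl on an aromatic carbon. Both groups are halogenated phenyl rings of the same heavy-atom count, so the change is a shift of halogen identity and ring position only. Among the measured compounds shown here, with no measured step to draw on, the expected step of a 1.1-fold higher number from compound 2 to compound 3 (0.05 log units; within the scatter) is none beyond the scatter. Compound 3 is therefore estimated at 300 nM in this assay, with a range from 120 nM to 800 nM.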

Compound 3, half-maximal inhibitory concentration: 302 nM
Beside the measured number, compound 3's estimate is 1.0-fold (0.00 log units) below it; low and high end bracket the measured number.
By their numbers in this assay, from the lowest: compounds 2, 3 and 1 (each within the scatter of the next).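

Among these compounds, this is the first step that can be read. In this assay, 3-bromophenyl in place of 2-chlorophenyl, on the aromatic carbon next to the ring nitrogen, gives a 1.1-fold higher number from compound 2 to compound 3 (0.05 log units; within the scatter), so these two halogenated phenyl rings are not told apart at this carbon by this read-out. The swap changes halogen identity and ring placement at once, so the step shows only the sum of the two changes, and two opposing contributions cannot be excluded. No measurement at hand offers an account of this result.

From the compounds shown here alone, a 3-chlorophenyl or a 2-bromophenyl on the same carbon would separate the halogen from its ring placement, and that split remains open. Also open, going by these compounds, is whether the number moves beyond the scatter at this carbon with a phenyl ring carrying an amine or a carboxylic acid, or with a longer alkyl chain in place of the ring.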